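Fluoro for methyl on the sulfonyl ring: compound 4

This account rests on a few compounds, and the source may have more. Where it says the series, first, only, none or still open, it means among the compounds named here.

Compound 1 `COc1ncc(-c2ccc3nc(N)nn3c2)cc1NS(=O)(=O)c1ccc(F)cc1` and compound 2 `COc1ncc(-c2ccc3nc(N)nn3c2)cc1NS(=O)(=O)c1ccc(C)cc1` share one core and differ only on the aryl ring of the sulfonamide. In a functional assay on HCT-116 cells (Homo sapiens) for antiproliferative activity, read by MTT assay, with a stated time of 48 h (a lower number here means a stronger inhibitor, a higher number a weaker inhibitor), compound 1 gives 2970 nM, and compound 2 gives 3400 nM; the two numbers lie within the scatter of each other, so no order is read between them. The change between them is fluoro in place of methyl on an aromatic carbon, and it made a 1.1-fold lower number from compound 2 to compound 1 (0.06 log units; within the scatter).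

Compound 3 `COc1ncc(-c2ccn3nc(NC(C)=O)nc3c2)cc1NS(=O)(=O)c1ccc(C)cc1` carries a different core; the difference between the two cores is not broken down here. In this assay compound 3 gives 1380 nM, the lowest of the three numbers, beyond the scatter from compound 1 and from compound 2.

Compound 4 `COc1ncc(-c2ccn3nc(NC(C)=O)nc3c2)cc1NS(=O)(=O)c1ccc(F)cc1` is still to be measured in this assay. It stands to compound 3 as compound 1 stands to compound 2: the change is fluoro in place of methyl on an aromatic carbon, the same change made once before, at a place described in the same words. Going by the values given here, only one measured instance of it exists, and that on the other core, so the transfer rests on a single pair.

The step from compound 3 is expected to be small, a 1.1-fold lower number from compound 3 to compound 4 (0.03 log units; within the scatter), set beside the earlier 1.1-fold lower number from compound 2 to compound 1 (0.06 log units; within the scatter), because a 1.1-fold lower number from compound 2 to compound 1 (0.06 log units; within the scatter) stayed within the scatter. Compound 4 is therefore expected at 1300 nM, with a range estimated from 650 nM to 2700 nM.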

Compound 4, half-maximal inhibitory concentration: 1320 nM
Compound 4: the middle estimate sits 1.0-fold (0.01 log units) below what was measured, and the stated range covers the measured number.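

On the core of compound 3, fluoro in place of methyl on an aromatic carbon gave a 1.0-fold lower number from compound 3 to compound 4 (0.02 log units; within the scatter), so in this assay this change separates compound 3 and compound 4 no more than repeated measurement would. Set beside the earlier pair, the change reads the same on both cores: the same change on two cores in this assay, a 1.1-fold lower number (0.06 log units; within the scatter) from compound 2 to compound 1 and a 1.0-fold lower number (0.02 log units; within the scatter) from compound 3 to compound 4, 1.1-fold (0.04 log units) apart, within the scatter of two such steps

This shows that, for these two pairs, going from 4-methylphenyl to 4-fluorophenyl left the number within the scatter on either core, but it rests on two steps only and gives no rule for the series, no reason for the agreement and no information beyond this one cell read-out.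

The compounds shown hold only methyl and fluoro at this place on the sulfonyl ring, so it remains open whether chloro, trifluoromethyl, methoxy, a longer chain such as propyl, an amine or a carboxylic acid there would give a step beyond the scatter, and whether such a step would carry from one core to the other. Also open, as far as these compounds go, is how much of the difference in numbers between the two cores belongs to the core itself and how much to its amino or acetylamino group.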